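From phenyl to 4-methylphenyl: one methyl, one open question

A few compounds are considered here, and "the series" means these few. Any claim that something is new, unique, unknown or untested is made for them only; others in the source may bear on it.

Compound 1 `COc1cc(OC)c(OC)cc1/C=C/C(=O)c1cc(OC(C)=O)ccc1OC(C)=O` gives 57900 nM
Compound 2 `COc1cc(OC)c(OC)cc1/C=C/C(=O)c1ccccc1` gives > 150000 nM

Both entries come from a functional assay on HeLa cells (Homo sapiens) for inhibition, read by MTT assay, with a stated time of 72 h; on this read-out higher numbers stand for weaker inhibition and lower numbers for stronger inhibition. Compound 1 gives a real number on this read-out. For compound 2 the entry > 150000 nM is a limit of the assay and not a number. Compound 2 thus stands at the limit of > 150000 nM in this assay, at which 1 of the 2 values shown sits, and it offers no exact point from which to count.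

Compound 3 `COc1cc(OC)c(OC)cc1/C=C/C(=O)c1ccc(C)cc1` keeps the core of compound 2 and changes it in one place: methyl in place of hydrogen on an aromatic carbon. In words, this is methyl in place of hydrogen on an aromatic carbon, turning phenyl into 4-methylphenyl. No measured pair among these compounds shows what such a change does. In this assay no shift beyond the usual scatter is therefore expected, and no direction can be favoured. The estimated size of the move is a number no higher from compound 2 to compound 3 (the limit leaves the size open). Compound 3 is expected to read 150000 nM, with an estimated range of 70000 nM to 300000 nM.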

Compound 3, half-maximal inhibitory concentration: 42200 nM
Compound 3: middle estimate off by 3.6-fold (0.55 log units), on the high side, outside the stated range (below it).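

In this assay, a single methyl on an aromatic carbon, para to a large group, gives an at least 3.5-fold lower number from compound 2 to compound 3 (0.55 log units; beyond the scatter). Among the compounds shown here, this is the first sign that this position of the ring responds to substitution, and that one added carbon, with no hydrogen-bond donor or acceptor and no net charge, is enough to produce a shift beyond the usual scatter. The entry for compound 2 is a limit and not a number, so the step has a floor but no known full size: the limit of > 150000 nM in this assay, at which 1 of the 3 values shown sits.

The compounds shown do not say whether this effect belongs to methyl in particular or would appear with other groups on the same carbon, such as a longer chain like ethyl, a methoxy group, an amine or a carboxylic acid, nor in which direction any of these would move the number. They also leave open whether methyl would do the same on another carbon of this ring, and whether the step would hold on a core other than that of compound 2.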